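Replacing Dimethylamino with 4-Methylpiperazin-1-yl

The compounds below may be only part of what the source reports. "The series", "measured", "known", "first", "only" and "open" are said of these compounds alone.

Two related compounds provide the starting point in an ADME assay on a cell-free system (plasma, Homo sapiens) for protein binding. There, compound 1 `CNc1nccc(N2CC[C@H](NC(=O)Nc3ccc(CN(C)C)c(C(F)(F)F)c3)C2)n1` gives 94.3%, and compound 2 `CNc1nccc(N2CC[C@H](NC(=O)Nc3ccc(OC)cc3)C2)n1` gives 80%. Compound 1 therefore has the lower unbound fraction of the two, and the gap between them lies beyond the usual scatter.

Compound 3 `CNc1nccc(N2CC[C@H](NC(=O)Nc3ccc(CN4CCN(C)CC4)c(C(F)(F)F)c3)C2)n1` differs from compound 1 in one place: 4-methylpiperazin-1-yl in place of dimethylamino on a saturated chain carbon bound to an aromatic carbon. In words, 4-methylpiperazin-1-yl stands in place of dimethylamino on a saturated chain carbon bound to an aromatic carbon.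

Among the measured compounds shown here, no measured pair shows this exchange, and compounds 1 and 2 differ in more than one place, so their gap cannot show what this change alone will do. The expectation therefore starts from compound 1 at 94.3% and assumes that a single change leaves most of the structure untouched. A slight fall in this assay is expected, with no step beyond the scatter. The expected step is a 1.4-fold higher unbound fraction from compound 1 to compound 3 (0.15 log units; within the scatter). For compound 3, the estimated value is 92%, with an expected range from 85% to 97%.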

Compound 3, plasma protein binding: 87.6%
The estimate for compound 3 lay 1.6-fold (0.19 log units) (unbound fraction) below the measured number, and the stated range covers the measured number.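

Among the compounds shown here, this pair is the first that differs in one place only, so it isolates what the group on the saturated chain carbon bound to an aromatic carbon does in this assay. Exchanging dimethylamino for 4-methylpiperazin-1-yl gives a 2.2-fold higher unbound fraction from compound 1 to compound 3 (0.34 log units; beyond the scatter), a modest step that still lies beyond the scatter, so this position can change how much of the compound stays free even with the rest of the structure held constant. No measurement at hand gives a reason for this step.

The compounds shown do not separate the contribution of the six-membered ring from that of its second nitrogen and the methyl group it carries, and a piperidin-1-yl or morpholin-4-yl group at the same place would speak directly to that question. From the compounds shown here alone, it also remains open whether the exchange would produce a step of similar size on a compound in which a hydrogen or a chlorine stands in place of the trifluoromethyl group.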